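This account rests on a few compounds, and the source may have more. Where it says the series, first, only, none or still open, it means among the compounds named here.

Measured so far in a functional assay on SK-OV-3 cells (Homo sapiens) for cytotoxicity, read by sulforhodamine B assay, with a stated time of 2 days, tested at 100 uM; on this read-out lower numbers stand for less inhibition and higher numbers for more inhibition at the one concentration tested (going by the name of the read-out):
Compound 1 `O=C(Nn1c(-c2cccc([N+](=O)[O-])c2)nc2c(-c3ccco3)n[nH]c2c1=O)c1cccnc1` gives -0.61%.
Compound 2 `COc1cccc(-c2nc3c(-c4ccco4)n[nH]c3c(=O)n2NC(=O)c2cccnc2)c1` gives 25%.
Compound 3 `O=C(Nn1c(-c2cccc([N+](=O)[O-])c2)nc2c(-c3ccc(Cl)cc3)n[nH]c2c1=O)c1ccccc1` gives 86.8%.

Compound 4 `COc1cccc(-c2nc3c(-c4ccc(Cl)cc4)n[nH]c3c(=O)n2NC(=O)c2ccccc2)c1` has not yet been measured. It differs from compound 3 in one place: methoxy in place of nitro on an aromatic carbon. The same change, at the same place, already links two measured compounds, compound 1 and compound 2: methoxy in place of nitro on an aromatic carbon. That earlier step gave a number 25.6 percentage points higher from compound 1 to compound 2 (beyond the scatter). The cores carrying the change are not the same, however: the difference between the core of compound 1 and the core of compound 3 is not broken down here. Compound 3 stands highest of the three measured compounds, and its number in this assay already lies near the top of the scale at the single concentration tested, so there is little room for a step of the earlier size in the upward direction. For compound 4 the expected step is a number 1.2 percentage points higher from compound 3 to compound 4 (within the scatter), resting on the direction of the earlier step and on the high starting point of compound 3. The estimate for compound 4 is 88%, expected to fall between 65% and 100%.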

Compound 4, a percentage reported as inhibition, at one concentration (the size of the read-out at that concentration, not a potency): 81.7%
For compound 4 the middle estimate is 6.3 percentage points above the measured one; the measured number falls inside the stated range.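

In this assay, putting 3-methoxyphenyl in place of 3-nitrophenyl on the core of compound 3 gives a number 5.1 percentage points lower from compound 3 to compound 4 (within the scatter), so on this core the swap makes no difference that can be told apart from repeat scatter. The change therefore does not carry over from one core to the other with the same size: the same change on two cores in this assay, a number 25.6 percentage points higher (beyond the scatter) from compound 1 to compound 2 and a number 5.1 percentage points lower (within the scatter) from compound 3 to compound 4, 30.7 percentage points apart, beyond the scatter of two such steps. This does not show which part of the cores sets the two steps apart, as the difference between them is not broken down here, and with compound 3 at 86.8% near the top of the scale, two pairs at a single concentration give no rule for the series.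

As far as these compounds go, whether an amine or a carboxylic acid on that same aromatic carbon would follow methoxy on either core remains open. Also open, from the compounds shown here alone, is how the swap behaves on further cores, and whether the two steps would still differ at other concentrations.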